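The source may report more compounds than this note shows. Statements on the series, on what has been measured and on what is new or still open speak of the compounds shown alone.

Of the compounds shown here, three sharing one core have been tested in a functional assay on MCF7 cells (Homo sapiens) for cytotoxicity, read by MTT assay; a lower number here means a stronger inhibitor, a higher number a weaker inhibitor. Compound 1 `COCOc1cc(C#Cc2cc(OC)c(OC)c(OC)c2)ccc1OC` gives 25600 nM. Compound 2 `COc1ccc(C#Cc2cc(OC)c(OC)c(OC)c2)cc1O` gives 1640 nM, and the change from compound 1 to compound 2, hydrogen in place of methoxymethyl on an oxygen on an aromatic ring, brings a 16-fold lower number from compound 1 to compound 2 (1.19 log units; beyond the scatter). Compound 3 `COc1ccc(C#Cc2cc(OC)c(OC)c(OC)c2)cc1N` reaches only the upper limit of this assay, reported as > 30000 nM, so no exact number is known for it. Measured against the others, this means an at least 1.1-fold higher number from compound 1 to compound 3 (0.06 log units; that floor lies within the scatter) and an at least 18-fold higher number from compound 2 to compound 3 (1.26 log units; beyond the scatter), with compound 3 standing as the weakest of the three where the comparison to compound 2 is concerned, in line with the limit of > 30000 nM in this assay, at which 1 of the 3 values shown sits.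

Compound 4 `COc1ccc(C#Cc2cc(OC)c(OC)c(OC)c2)cc1NC(=O)OC(C)(C)C` is not yet measured. It differs from compound 3 in one place: tert-butoxycarbonyl in place of hydrogen on a nitrogen on an aromatic ring. The closest measured precedent is the step from compound 1 to compound 2, where removing a capping group on an oxygen gave a 16-fold lower number from compound 1 to compound 2 (1.19 log units; beyond the scatter); here a capping group is added to a nitrogen, so the reverse direction, or no change beyond the scatter, is expected. Compound 4 is therefore expected to give 40000 nM, with a range from 15000 nM to 100000 nM, and the expected step is a step that the limit leaves unreadable from compound 3 to compound 4.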

Compound 4, half-maximal inhibitory concentration: > 30000 nM
Compound 4: a limit, no number; the forecaster's own chance of this, stated with the estimate: 70%; the middle value does not contradict the limit.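

In this assay compound 4 gives > 30000 nM, which is a limit of the assay and not a number. Placing (tert-butoxycarbonyl)amino on this aromatic carbon in place of hydroxy brings an at least 18-fold higher number from compound 2 to compound 4 (1.26 log units; beyond the scatter), so capping the nitrogen does not recover the lower number seen with hydroxy, whereas an at least 1.1-fold higher number from compound 1 to compound 4 (0.06 log units; that floor lies within the scatter) has a floor within the scatter and does not separate those two compounds. The step between compound 3 and compound 4 cannot be read, because both compounds sit at the same limit: the limit of > 30000 nM in this assay, at which 2 of the 4 values shown sit.

Going by these compounds, how far compound 3 and compound 4 lie beyond that limit remains open. Also open, on these data alone, is whether a smaller group on this nitrogen, such as acetyl or methyl, or a fluorine atom on this aromatic carbon, would give a readable value.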